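This account rests on a few compounds, and the source may have more. Where it says the series, first, only, none or still open, it means among the compounds named here.

Three compounds with the same core, differing only in the ring on the double-bonded chain, have been measured in a functional assay on PC-3 cells (Homo sapiens) for cytotoxicity, read by MTT assay, with a stated time of 72 h; on this read-out lower numbers stand for stronger inhibition and higher numbers for weaker inhibition. There compound 1 (`COc1cc2ncnc(Nc3ccc(F)c(Cl)c3)c2cc1NC(=O)/C=C/c1ccc(F)cc1Cl`) gives 32700 nM, compound 2 (`COc1cc2ncnc(Nc3ccc(F)c(Cl)c3)c2cc1NC(=O)/C=C/c1ccccc1[N+](=O)[O-]`) gives 14300 nM and compound 3 (`COc1ccc(/C=C/C(=O)Nc2cc3c(Nc4ccc(F)c(Cl)c4)ncnc3cc2OC)c(OC)c1`) gives 38500 nM. Compound 3 thus shares the upper end of this narrow range, the measured steps being a 1.2-fold higher number from compound 1 to compound 3 (0.07 log units; within the scatter) and a 2.7-fold higher number from compound 2 to compound 3 (0.43 log units; beyond the scatter).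

Compound 4 (`COc1cc2ncnc(Nc3ccc(F)c(Cl)c3)c2cc1NC(=O)/C=C/c1ccc(C#N)cc1`) has 4-cyanophenyl in place of 2,4-dimethoxyphenyl, on a double-bonded chain carbon bound to a double-bonded chain carbon: 4-cyanophenyl in place of 2,4-dimethoxyphenyl on a double-bonded chain carbon bound to a double-bonded chain carbon. For the measured compounds named here, no measured compound carries 4-cyanophenyl, so the evidence is indirect. The three ring swaps at this place include the one just given and a 2.3-fold lower number from compound 1 to compound 2 (0.36 log units; beyond the scatter), and none goes beyond a modest size. With compound 3 at 38500 nM, a new ring seems likelier to land lower than higher, though not clearly beyond the scatter. The expected change is a 1.8-fold lower number from compound 3 to compound 4 (0.24 log units; within the scatter). In this assay, compound 4 is estimated at 22000 nM, within an expected range of 10000 nM to 48000 nM.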

Compound 4, half-maximal inhibitory concentration: "not active" (no number reported)
For compound 4 the study gives words and no number; no gap can be computed for the estimate.
By their numbers in this assay, from the lowest: compound 2; then compounds 1 and 3 (each within the scatter of the next).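

In this assay, for the compounds shown here, compound 4 is reported only in words, as "not active", so no step to it from compound 1, compound 2 or compound 3 can be read. The compounds shown leave open how far compound 4 lies from compound 3 on this read-out. Nothing shown bears on this result.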